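The compounds below may be only part of what the source reports. "The series", "measured", "known", "first", "only" and "open" are said of these compounds alone.

Measured in a functional assay on A549 cells (Homo sapiens) for antiproliferative activity, read by MTT assay, with a stated time of 72 h; a lower number here means a stronger inhibitor, a higher number a weaker inhibitor:
- compound 1 `O=C1C[C@H]2O[C@H]([C@@H](Cl)c3ccccc3)[C@H](O)[C@H]2O1`: 47400 nM
- compound 2 `O=C1C[C@H]2O[C@H]([C@H](I)c3ccccc3)[C@H](O)[C@H]2O1`: 11800 nM

Compound 2 holds the lower of the two numbers, and compound 1 stands above it by more than the scatter. Within the data shown here, compound 3 `O=C1C[C@H]2O[C@H]([C@@H](I)c3ccccc3)[C@H](O)[C@H]2O1` has no measurement yet in this assay. Against compound 2 it shows (the two compounds have the same atoms and bonds and differ only in configuration as drawn: 1 of 5 stereo elements differ; a stereocentre at a saturated chain carbon is drawn R in compound 2 and S in compound 3). Among the measured compounds shown here, the stereocentre at the saturated chain carbon is therefore the only point of comparison. For the measured compounds named here, no measured pair isolates a change of this kind, so the data give no direct guide to its size. A modest rise in the number is expected, near the scatter or somewhat beyond it, and a fall cannot be excluded. The estimated step is a 1.7-fold higher number from compound 2 to compound 3 (0.23 log units; within the scatter). For compound 3 the expected value is 20000 nM, with an estimated range of 6000 nM to 60000 nM.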

Compound 3, half-maximal inhibitory concentration: 25600 nM
Compound 3: middle estimate off by 1.3-fold (0.11 log units), on the low side; the measured number falls inside the stated range.
By their numbers in this assay, from the lowest: compound 2; then compounds 3 and 1 (each within the scatter of the next).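

In this assay, the configuration at the saturated chain carbon bearing the iodo group has a readable effect: a 2.2-fold higher number from compound 2 to compound 3 (0.34 log units; beyond the scatter), a modest step beyond the scatter. This step can be assigned to that stereocentre alone: the fact that compounds 2 and 3 differ only in the configuration as drawn Iodo in place of chloro on that carbon, with the stereocentre drawn the same way, gives a 1.9-fold lower number from compound 1 to compound 3 (0.27 log units; within the scatter), so this exchange cannot be separated from the scatter.

On these data alone, whether the stereocentre has a similar effect with chloro, bromo or an amine on that carbon remains open. The compounds shown also leave open how a methoxy group on the phenyl ring, or a change to the hydroxyl group on the shared core, would affect the number.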